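Cytotoxicity notes on a heteroaryl swap in the diarylpyrimidine series

The compounds below may be only part of what the source reports. "The series", "measured", "known", "first", "only" and "open" are said of these compounds alone.

Measured so far in a toxicity assay on MT4 cells (Homo sapiens) for cytotoxicity, read by MTT assay, with a stated time of 5 days; a higher number here means that more compound is tolerated, a lower number that less compound is tolerated:
- compound 1 `Cc1cnc(Nc2ccc(C#N)cc2)nc1Nc1c(F)cc(-c2cccnc2)cc1F` gives 1100 nM
- compound 2 `Cc1cnc(Nc2ccc(C#N)cc2)nc1Nc1c(F)cc(-c2ccoc2)cc1F` gives 4200 nM
- compound 3 `Cc1cc(-c2cncnc2)cc(C)c1Nc1ccnc(Nc2ccc(C#N)cc2)n1` gives 6800 nM

Compound 3 has the highest number of the three. Its gap to compound 2 lies within the scatter, so nothing can be said of an order between these two; its gap to compound 1 lies beyond the scatter, so more of compound 3 than of compound 1 is tolerated.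

Compound 4 `Cc1cc(-c2cc(F)nc(F)c2)cc(C)c1Nc1ccnc(Nc2ccc(C#N)cc2)n1` is not yet measured. It differs from compound 3 in one place: 2,6-difluoropyridin-4-yl in place of pyrimidin-5-yl on an aromatic carbon.

Among the compounds with values here, the only step in hand is a 3.8-fold higher number from compound 1 to compound 2 (0.58 log units; beyond the scatter), and it is also a swap of one aromatic ring for another on an aromatic carbon, though on a different core and between rings of different size. Within the data shown here, it shows that such a swap can move the number in this assay modestly, and no step shows the direction for a six-membered ring replaced by a six-membered ring bearing fluorine. The expectation for compound 4 is therefore a small step, a 1.4-fold lower number from compound 3 to compound 4 (0.13 log units; within the scatter), most likely within the scatter. Compound 4 is estimated at 5000 nM, in the range 1800 nM to 14000 nM.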

Compound 4, half-maximal cytotoxic concentration: 6300 nM
For compound 4 the middle estimate is 1.3-fold (0.10 log units) below the measured one; measured number inside the range.
By their numbers in this assay, from the lowest: compound 1; then compounds 2, 4 and 3 (each within the scatter of the next).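

In this assay the exchange of pyrimidin-5-yl for 2,6-difluoropyridin-4-yl gives a 1.1-fold lower number from compound 3 to compound 4 (0.03 log units; within the scatter), so at this place, on an aromatic carbon meta to two methyl groups, the two rings cannot be told apart in this read-out. Within the data shown here, this is the first one-place step on the core of compound 3, and it shows that a larger group with fewer ring hetero atoms and fewer hydrogen-bond acceptors, carrying two fluorine atoms, leaves the number unresolved from that of the pyrimidin-5-yl compound, whereas the only earlier step, on the core of compound 1, lay beyond the scatter. Nothing measured on these compounds accounts for this result, and the flat step alone does not supply a reason.

The compounds shown leave open whether this place stays as insensitive when the aromatic ring gives way to a non-aromatic group such as an amine or a carboxylic acid. They also leave open how pyridin-3-yl or furan-3-yl would read on the core of compound 3, and how the two rings of this step would read on the core of compound 1.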